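Amide-to-carbamoyl exchange on the shared core of compound 2

The compounds below may be only part of what the source reports. "The series", "measured", "known", "first", "only" and "open" are said of these compounds alone.

Measured so far:
Compound 1 `COc1ccc([N+](=O)[O-])cc1CSc1nc2cc(NC(=O)NC(C)(C)C)ccc2n1Cc1ccncc1` — in an assay on isolated protein for inhibition of Gonadotropin-releasing hormone receptor (Homo sapiens) (a lower number here means a stronger inhibitor, a higher number a weaker inhibitor), compound 1 gives 47 nM.
Compound 2 `COc1ccc([N+](=O)[O-])cc1CSc1nc2cc(NC(=O)C3CCC3)ccc2n1C(C)C` — in this assay compound 2 gives 1500 nM.

Compound 2 stands at the higher of the two numbers. Among the measured compounds shown here, the nearest, compound 1, sits at a much lower number, beyond the scatter, yet the two differ at more than one place, so no single step between them is known. Compound 3 `COc1ccc([N+](=O)[O-])cc1CSc1nc2cc(NC(=O)NC(C)C)ccc2n1C(C)C` keeps the core and the isopropyl of compound 2 and alters only the acyl part: isopropylamino in place of cyclobutyl on a carbonyl carbon. For the measured compounds named here, no measured pair isolates this change; the only hint is that compound 1, which also carries a carbamoylamino-type substituent, gives 47 nM in this assay. A moderate fall in the number is expected for this step, a 3.0-fold lower number from compound 2 to compound 3 (0.48 log units; beyond the scatter). Compound 3 is accordingly estimated at 500 nM, with a range from 150 nM to 2000 nM.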

Compound 3, half-maximal inhibitory concentration: 600 nM
Beside the measured number, compound 3's estimate is 1.2-fold (0.08 log units) below it; measured number inside the range.
By their numbers in this assay, from the lowest: compound 1; then compound 3; then compound 2.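

In this assay, among the compounds shown here, a 2.5-fold lower number from compound 2 to compound 3 (0.40 log units; beyond the scatter) gives the first reading at this position: a modest step, beyond the scatter, for isopropylamino in place of cyclobutyl on a carbonyl carbon, with the rest of compound 2 unchanged. The heavy-atom count stays the same, but the four-membered ring leaves while a nitrogen and a hydrogen-bond donor enter, so this single step does not separate those changes. No measurement available here accounts for the step.

Cyclobutylamino on the same carbonyl carbon, or isopropyl there, would help show whether the step follows the loss of the ring or the entry of the nitrogen. Compound 1 differs from compound 3 in more than one place, so the contribution of each place to the difference between their values cannot be read.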